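The source may hold more compounds than are shown below. What is called first, only, known or untested is meant among the compounds shown, and "the series" means these compounds.

Going by the values given here, compound 1 `Cc1ccccc1NC(=O)Nc1cccc(CNc2ncnc3ccccc23)c1` is the only member of the series with a number in a functional assay on A549 cells (Homo sapiens) for antiproliferative activity, read by MTT assay; a lower number here means a stronger inhibitor, a higher number a weaker inhibitor: compound 1 gives 40200 nM. Compound 2 `O=C(Nc1cccc(Cl)c1)Nc1cccc(CNc2ncnc3ccccc23)c1` reaches only a limit of the assay, (the limit of > 50000 nM in this assay, at which 1 of the 2 values shown sits), and in this assay compound 2 gives > 50000 nM. The step of an at least 1.2-fold higher number from compound 1 to compound 2 (0.09 log units; that floor lies within the scatter) is therefore a floor and lies within the scatter. Compound 3 `O=C(Nc1ccc([N+](=O)[O-])cc1)Nc1cccc(CNc2ncnc3ccccc23)c1` carries 4-nitrophenyl in place of 2-methylphenyl on an amide-type nitrogen. Among the compounds with values here, the only measured step at this position gives no movement beyond the scatter, so for compound 3 a step of about a 1.2-fold higher number from compound 1 to compound 3 (0.09 log units; within the scatter) is expected, with a fair chance of a limit. Compound 3 is estimated at 50000 nM, between 20000 nM and 120000 nM.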

Compound 3, half-maximal inhibitory concentration: > 50000 nM
Compound 3 ended at the assay's limit (the forecaster's own chance of this, stated with the estimate: 55%); the middle value sits exactly at the limit.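

With 4-nitrophenyl in place of 2-methylphenyl on the amide-type nitrogen, this assay gives an at least 1.2-fold higher number from compound 1 to compound 3 (0.09 log units; that floor lies within the scatter), so a second replacement at this position also yields only a floor. Compound 2 and compound 3 are both limits, and the step between them cannot be read. Compound 1 remains the only compound here with a number, and the limit now covers most of the series: the limit of > 50000 nM in this assay, at which 2 of the 3 values shown sit.

On these data alone, it remains open how far compound 3 lies from compound 1. As far as these compounds go, it is also open whether an amine, a carboxylic acid or a longer alkyl chain at this position would give a reading inside the assay's range.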